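Smaller alkyl on the fused ring of compound 2

A few compounds are considered here, and "the series" means these few. Any claim that something is new, unique, unknown or untested is made for them only; others in the source may bear on it.

Compound 1 `CCC1Nc2ccccc2C(=O)N1Cc1ccc(-c2ccccc2-c2nn[nH]n2)cc1` carries hydrogen on the fused aromatic ring, and in a functional assay on the whole organism for inhibition, with Rattus norvegicus as the target, at a dose of 15 mg/kg by the intravenous route (on this read-out higher numbers stand for more inhibition at the one dose given (going by the name of the read-out) and lower numbers for less inhibition), compound 1 gives 88%. Compound 2 `CCC1Nc2ccc(C(C)C)cc2C(=O)N1Cc1ccc(-c2ccccc2-c2nn[nH]n2)cc1` carries isopropyl on an aromatic carbon of that ring, and in this assay compound 2 gives 88%. Among the measured compounds shown here, the single measured step, no change at the digits printed from compound 1 to compound 2 (within the scatter), shows isopropyl in place of hydrogen on an aromatic carbon leaving the read-out where it was. Compound 2 therefore stands level with compound 1 at the digits shown, within the scatter.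

Compound 3 `CCC1Nc2ccc(C)cc2C(=O)N1Cc1ccc(-c2ccccc2-c2nn[nH]n2)cc1` differs from compound 2 in one place: methyl in place of isopropyl on an aromatic carbon. For the measured compounds named here, only the step from compound 1 to compound 2 bears on this change, since it also exchanges the group on an aromatic carbon of the fused ring; that step was flat. Methyl lies between hydrogen and isopropyl in what is counted, so no step beyond the scatter is expected in this assay on going from compound 2 to compound 3. The estimate for compound 3 is 88%, with a range of 78% to 96%. The expected step is no change at the digits printed from compound 2 to compound 3 (within the scatter), that is, none beyond the scatter.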

Compound 3, a percentage reported as inhibition, in the whole organism at one dose (the size of the read-out at that dose, not a potency): 88%
The estimate for compound 3 equals the measured number at the digits printed; the range from low to high includes it.
By their numbers in this assay, from the lowest: compounds 1, 2 and 3 (each within the scatter of the next).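

Working notes on the aromatic carbon of the fused ring: in this assay, methyl in place of isopropyl gives no change at the digits printed from compound 2 to compound 3 (within the scatter), and methyl in place of hydrogen gives no change at the digits printed from compound 1 to compound 3 (within the scatter), so this position now has a group of intermediate size to set against the two earlier end points. Hydrogen, methyl and isopropyl all read alike here, which means the flat result is no longer a single comparison resting on isopropyl alone but holds across all three pairs of these compounds, on this one carbon, at this one dose and by this one route. No measurement offered here accounts for this flat reading.

Open, from the compounds shown here alone, is whether a group of another kind on the same carbon, such as an amine, a carboxylic acid or a longer chain, would keep the read-out in this assay level with these three compounds. Also open, going by these compounds, is whether the three would still read alike at a lower dose, and whether methyl or isopropyl would do so on another carbon of the ring.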